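This account rests on a few compounds, and the source may have more. Where it says the series, first, only, none or still open, it means among the compounds named here.

Compound 1, `N#CN1CC(OCc2ccc(Oc3ccccc3)cc2Br)C1`, gives 1.03 nM in an assay on isolated protein for inhibition of N-acylethanolamine-hydrolyzing acid amidase (Homo sapiens), read by fluorescence, with a stated time of 90 min; a higher number here means a weaker inhibitor, a lower number a stronger inhibitor. Compound 2, `COc1ccc(-c2cc(Oc3ccccc3)ccc2COC2CN(C#N)C2)cc1`, gives 5.7 nM in this assay. Compound 3, `N#Cc1ccc(-c2cc(Oc3ccccc3)ccc2COC2CN(C#N)C2)cc1`, gives 2.5 nM in this assay.

Of the three measured compounds, compound 3 stands in the middle: the step is a 2.4-fold higher number from compound 1 to compound 3 (0.39 log units; beyond the scatter), and the step is a 2.3-fold lower number from compound 2 to compound 3 (0.36 log units; beyond the scatter), so compound 1 gives the lowest number and compound 2 the highest. Compound 4, `N#Cc1ccccc1-c1cc(Oc2ccccc2)ccc1COC1CN(C#N)C1`, differs from compound 3 by 2-cyanophenyl in place of 4-cyanophenyl on an aromatic carbon. Going by the values given here, no measured step moves a substituent within the attached phenyl ring; the steps that bear on the change are those that vary the group at this same aromatic carbon, namely a 2.4-fold higher number from compound 1 to compound 3 (0.39 log units; beyond the scatter) and a 2.3-fold lower number from compound 2 to compound 3 (0.36 log units; beyond the scatter), both of modest size. Since all three compounds fall within a narrow band in this assay, compound 4 is expected to land close to compound 3, with a change no larger than those modest steps and in no firmly predicted direction. Compound 4 is therefore estimated at 3.2 nM in this assay, with an expected range from 1.2 nM to 8.5 nM. This estimate corresponds to an expected step of a 1.3-fold higher number from compound 3 to compound 4 (0.11 log units; within the scatter).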

Compound 4, half-maximal inhibitory concentration: 6.6 nM
Compound 4: middle estimate off by 2.1-fold (0.31 log units), on the low side, within the range that was stated.
By their numbers in this assay, from the lowest: compound 1; then compound 3; then compounds 2 and 4 (each within the scatter of the next).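

Moving the nitrile within the attached phenyl ring, with the same atoms joined differently, gives a 2.6-fold higher number from compound 3 to compound 4 (0.42 log units; beyond the scatter) in this assay. Going by these compounds alone, this is the first sign that, at this aromatic carbon, the place of the substituent on the attached ring counts as well as its identity. The advantage of 4-cyanophenyl over 4-methoxyphenyl does not carry over to 2-cyanophenyl, as the change from 4-methoxyphenyl gives a 1.2-fold higher number from compound 2 to compound 4 (0.06 log units; within the scatter), while the change from bromo gives a 6.4-fold higher number from compound 1 to compound 4 (0.81 log units; beyond the scatter), so bromo keeps the lowest number. Nothing available here accounts for this shift. The compounds shown leave open whether methoxy responds to the same move as the nitrile does. They also leave open how an amine or a carboxylic acid in the nitrile's place would read in this assay.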